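The source may hold more compounds than are shown below. What is called first, only, known or untested is meant among the compounds shown, and "the series" means these compounds.

Measured in an ADME assay on A2780 cells (Homo sapiens) for inhibition, read by MTT assay, with a stated time of 72 h; a higher number here means a weaker inhibitor of growth, a lower number a stronger inhibitor of growth:
Compound 1 `CCCOc1ccc(/C=C/C(=O)c2ccc(O)cc2)cc1`: "not determined" (no result reported)
Compound 2 `COc1ccc(-c2c(OCC(=O)Nc3cccc4ccccc34)oc3ccccc3c2=O)cc1OC`: 43600 nM

Among the measured compounds shown here, compound 2 holds the only number in this assay series, since compound 1 has no reported result, so it cannot yet be ranked against anything. Compound 3 `Cc1ccc(-c2c(OCC(=O)Nc3cccc4ccccc34)oc3ccccc3c2=O)cc1` keeps the shared core and side chain of compound 2 and changes one substituent: 4-methylphenyl in place of 3,4-dimethoxyphenyl on an aromatic carbon. In words, 4-methylphenyl stands in place of 3,4-dimethoxyphenyl on an aromatic carbon. For the measured compounds named here, no step between measured compounds shows what such a swap does in this assay, so the data give no direction for it. With compound 2 at 43600 nM as the only anchor, the expected result is no change beyond the scatter, and the estimate is a 1.1-fold lower number from compound 2 to compound 3 (0.06 log units; within the scatter). For compound 3 the estimated value is 38000 nM, with an expected range from 13000 nM to 100000 nM.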

Compound 3, concentration for 50% growth inhibition: 68700 nM
For compound 3 the middle estimate is 1.8-fold (0.26 log units) below the measured one; the range from low to high includes it.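

In this assay, putting 4-methylphenyl in place of 3,4-dimethoxyphenyl on this aromatic carbon gives a 1.6-fold higher number from compound 2 to compound 3 (0.20 log units; within the scatter), the first step read at this position. The entering group has 0 hydrogen-bond acceptors and the leaving group has 2, yet this change does not separate the two compounds beyond the scatter. No other measurement bears on this result.

The compounds shown leave open whether any other group at this position, such as a phenyl ring carrying an amine or a carboxylic acid, would move the number beyond the scatter. They also leave open whether a change elsewhere, such as a longer chain between the ring oxygen and the amide, would alter the growth inhibition.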